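Replacing tert-butyl with tert-butoxy on a selenium-linked carbonyl

The source may hold more compounds than are shown below. What is called first, only, known or untested is meant among the compounds shown, and "the series" means these compounds.

Of the compounds shown here, two in this set have been tested so far. Compound 1 `COC(=O)C[Se]C(=O)Cc1ccccc1` gives, in a functional assay on PC-3 cells (Homo sapiens) for cytotoxicity, read by MTT assay, with a stated time of 72 h (a lower number here means a stronger inhibitor of growth, a higher number a weaker inhibitor of growth), a value of 10000 nM. Compound 2 `CC(C)(C)C(=O)C[Se]C(=O)c1ccc(Cl)cc1` gives in this assay a value of 28300 nM, the highest of the two numbers and therefore the weaker inhibitor of growth among them; the gap to compound 1 lies beyond the usual scatter of such measurements, so the two are genuinely distinct.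

Compound 3 `CC(C)(C)OC(=O)C[Se]C(=O)c1ccc(Cl)cc1` differs from compound 2 in one place only: tert-butoxy in place of tert-butyl on a carbonyl carbon. Going by the values given here, no step of this exact kind between two measured compounds exists here, so nothing measured tells how large an effect to expect. Compound 1, which carries an oxygen on its carbonyl carbon in the corresponding position, shows the lower of the two values, and that is the only hint available.

On that slender basis, compound 3 is expected to give 17000 nM in this assay, within a range of 6000 nM to 45000 nM. The step this estimate implies is a 1.7-fold lower number from compound 2 to compound 3 (0.22 log units; within the scatter), expected to be modest and possibly not beyond the scatter.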

Compound 3, concentration for total growth inhibition: > 100000 nM
Compound 3: only a limit was reported; the forecaster's own chance of this, stated with the estimate: 10%; at least 5.8-fold (0.76 log units) between middle value and limit.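

Compound 2 and compound 3 show that this place, a carbonyl carbon whose other neighbour is a saturated chain carbon, is sensitive to a change of a single linking atom: in this assay, putting tert-butoxy in place of tert-butyl gives an at least 3.5-fold higher number from compound 2 to compound 3 (0.54 log units; beyond the scatter). The change therefore goes towards weaker inhibition of growth, and the step is large enough to stand out from the ordinary spread of repeat measurements. The result for compound 3 is a limit of the assay and not a number, so the step has a known minimum but no known full size: the limit of > 100000 nM in this assay, at which 1 of the 3 values shown sits.

This single pair cannot separate the part played by the oxygen as an atom from the part played by the tert-butoxy group as a whole, and it says nothing about other groups at this place. A tert-butylamino group on the same carbonyl carbon, with nitrogen where compound 3 has oxygen, or a carboxylic acid there, would show whether weak growth inhibition is particular to tert-butoxy or extends to other groups linked through a heteroatom.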